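The source may report more compounds than this note shows. Statements on the series, on what has been measured and on what is new or still open speak of the compounds shown alone.

Measured in a functional assay on CWR22R cells (Homo sapiens) for antiproliferative activity, read by CCK-8 assay, with a stated time of 6 days; a higher number here means a weaker inhibitor, a lower number a stronger inhibitor:

- compound 1 `CCN(c1ccc(C#N)c(Cl)c1)c1cc(-c2c[nH]nc2C)ccc1C`: 5380 nM
- compound 2 `CCN(c1ccc(C#N)c(Cl)c1)c1cc(-n2cccn2)ccc1C`: > 30000 nM (a limit of the assay)
- compound 3 `CCN(c1ccc(C#N)c(Cl)c1)c1cc(-n2ccnc2)ccc1C`: > 30000 nM (a limit of the assay)

Compound 3 has no number, only a limit: it stands at the limit of > 30000 nM in this assay, at which 2 of the 3 values shown sit. Compound 4 `CCN(c1ccc(C#N)c(Cl)c1)c1cc(-c2ccoc2)ccc1C` carries furan-3-yl in place of 1H-imidazol-1-yl on an aromatic carbon, meta to a large group and para to a methyl group (furan-3-yl in place of 1H-imidazol-1-yl on an aromatic carbon).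

Going by the values given here, no measured step exchanges furan-3-yl, so the evidence is indirect. The two readable steps both start from the 3-methyl-1H-pyrazol-4-yl group of compound 1, and both lie beyond the scatter: an at least 5.5-fold higher number from compound 1 to compound 2 (0.74 log units; beyond the scatter) and an at least 5.5-fold higher number from compound 1 to compound 3 (0.74 log units; beyond the scatter). The third, a step that the two limits leave unreadable from compound 2 to compound 3, shows nothing about size.

Among the compounds with values here, compound 1 at 5380 nM is the only compound here with a number, so a five-membered aromatic ring at this place can give measurable activity in this assay, though only one such case is known. Compound 4 is therefore expected to move modestly towards a lower number, without being expected to pass compound 1. The expected change is estimated as an at least 1.5-fold lower number from compound 3 to compound 4 (0.17 log units; that floor lies within the scatter). A result that is again only a limit remains quite possible. For compound 4 the estimated value is 20000 nM, with an expected range from 7000 nM to 45000 nM.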

Compound 4, half-maximal inhibitory concentration: > 30000 nM
Compound 4: only a limit was reported; the forecaster's own chance of this, stated with the estimate: 45%; at least 1.5-fold (0.17 log units) between middle value and limit.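

In this assay compound 4 gives only a limit, > 30000 nM. Its furan-3-yl group joins the shared core through a ring carbon, as the 3-methyl-1H-pyrazol-4-yl group of compound 1 does, whereas the groups of compound 2 and compound 3 join through a ring nitrogen, so attachment through carbon does not by itself go with measurable activity here, and the change gives an at least 5.5-fold higher number from compound 1 to compound 4 (0.74 log units; beyond the scatter). Going by these compounds alone, the steps among compound 2, compound 3 and compound 4 cannot be read, and compound 1 remains the only compound here with a number, with the rest gathered at one limit: the limit of > 30000 nM in this assay, at which 3 of the 4 values shown sit.

The compounds shown leave open whether the methyl group or the ring nitrogen hydrogen of the 3-methyl-1H-pyrazol-4-yl group goes with the activity of compound 1, as the two are never separated here. They also leave open how a 1H-pyrazol-4-yl group without that methyl, or a five-membered ring carrying an amine or a carboxylic acid, would behave at this place.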